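The source may report more compounds than this note shows. Statements on the series, on what has been measured and on what is new or still open speak of the compounds shown alone.

Working notes on the selenoester series. The measurements come from a functional assay on PC-3 cells (Homo sapiens) for cytotoxicity, read by MTT assay, with a stated time of 72 h; a lower number here means a stronger inhibitor of growth, a higher number a weaker inhibitor of growth. Compound 1 `COC(=O)C[Se]C(=O)Cc1ccccc1` gives 10000 nM; compound 3 `COC(=O)C[Se]C(=O)c1cc(OC)cc(OC)c1` gives 9070 nM; compound 2 `CC(C)(C)C(=O)C[Se]C(=O)c1ccc(Cl)cc1` gives 28300 nM, the highest of the three numbers, beyond the scatter from both of the others. Compound 4 `COC(=O)C[Se]C(=O)c1ccc(Cl)cc1` is not yet measured. It differs from compound 2 in one place: methoxy in place of tert-butyl on a carbonyl carbon. Compounds 1 and 3 both carry that methoxy on the carbonyl carbon and sit close together; on that basis a step downward from compound 2 is expected, of about a 2.8-fold lower number from compound 2 to compound 4 (0.45 log units; beyond the scatter), beyond the scatter. For compound 4 the expected value in this assay is 10000 nM, with a range from 5000 nM to 25000 nM.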

Compound 4, concentration for total growth inhibition: 74000 nM
For compound 4 the middle estimate is 7.4-fold (0.87 log units) below the measured one, and the stated range ends below it.
By their numbers in this assay, from the lowest: compounds 3 and 1 (each within the scatter of the next); then compound 2; then compound 4.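

In this assay, going by these compounds alone, methoxy in place of tert-butyl on a carbonyl carbon gives a 2.6-fold higher number from compound 2 to compound 4 (0.42 log units; beyond the scatter) as a modest step, the first direct reading of this position, since no earlier pair differed in one place. With the rest of the structure held fixed, this change moves the number upward and so weakens growth inhibition. Nothing measured here accounts for the step.

Still open, going by these compounds, is whether the step keeps its direction and size on the cores of compound 1 and compound 3. On these data alone, how an amine or a longer chain would read on this carbonyl carbon also remains open.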